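Removing a Piperidinyl Ring from a Receptor Binder

A few compounds are considered here, and "the series" means these few. Any claim that something is new, unique, unknown or untested is made for them only; others in the source may bear on it.

Measured compounds:
compound 1 `CCCN(Cc1ccccc1)c1cc(C)nc2c(-c3ncc(C(F)(F)F)cc3Cl)c(C)nn12` – 1.7 nM
compound 2 `CCCN(CCC)c1cc(C)nc2c(-c3ncc(N4CCCCC4)cc3C)c(C)nn12` – 17 nM

Both compounds were tested in an assay on isolated protein for binding affinity to corticotropin-releasing factor receptor 1 (Homo sapiens); on this read-out lower numbers stand for stronger inhibition and higher numbers for weaker inhibition. Compound 1 gives 1.7 nM, while compound 2 gives 17 nM, the higher of the two numbers and therefore the weaker binder; the gap between them lies well beyond the usual scatter. Compound 3 `CCCN(CCC)c1cc(C)nc2c(-c3ncccc3C)c(C)nn12` has not yet been measured. It differs from compound 2 in one place: hydrogen in place of piperidin-1-yl on an aromatic carbon. In words, a hydrogen takes the place of the piperidin-1-yl group on the aromatic carbon. For the measured compounds named here, no measured pair shows the effect of such a change, so the expectation rests only on the two numbers above. Since compound 2 gives 17 nM, a modest step toward a weaker binder, a 2.4-fold higher number from compound 2 to compound 3 (0.37 log units; beyond the scatter), is expected, though it may fall inside the scatter. Compound 3 is therefore estimated at 40 nM, with a likely range from 10 nM to 200 nM.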

Compound 3, inhibition constant: 110 nM
The estimate for compound 3 lay 2.8-fold (0.44 log units) below the measured number; measured number inside the range.
By their numbers in this assay, from the lowest: compound 1; then compound 2; then compound 3.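

In this assay, for the compounds shown here, the step of a 6.5-fold higher number from compound 2 to compound 3 (0.81 log units; beyond the scatter) gives the first direct reading of this position, on the aromatic carbon two atoms from the ring nitrogen. It shows that, with the rest of the molecule held constant, the version carrying piperidin-1-yl binds more strongly than the version carrying only hydrogen, something the gap between compound 1 and compound 2 could not show, as those two differ in more than one place. Nothing available explains why this change weakens binding.

As far as these compounds go, it remains open whether the whole six-membered ring is needed or a smaller group would serve as well, such as dimethylamino or a simple methoxy group. Morpholine at the same carbon would test whether swapping one ring carbon for oxygen alters the number.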